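The compounds below may be only part of what the source reports. "The series", "measured", "known", "first", "only" and "open" are said of these compounds alone.

Measured so far in an ADME assay on MT4 cells (Homo sapiens) for cytotoxicity, read by MTT assay; on this read-out higher numbers stand for lower toxicity in this test and lower numbers for higher toxicity in this test:
- compound 1 `O=C(CSc1nnnn1-c1cccc2ccccc12)N/N=C/c1cccs1`: > 316000 nM
- compound 2 `O=C(CSc1nnnn1-c1cccc2ccccc12)N/N=C/c1ccc(Cl)cc1`: > 295000 nM
- compound 3 `COc1ccc(/C=N/NC(=O)CSc2nnnn2-c2cccc3ccccc23)cc1OC`: 191000 nM

The value of compound 1 in this assay is a limit of the measurement, not a number. The value of compound 2 is likewise a limit. Compound 3 is the only one of the three with a number, so compound 1 cannot be placed in order against it beyond what an at least 1.6-fold lower number from compound 1 to compound 3 (0.21 log units; that floor lies within the scatter) shows, and a step that the two limits leave unreadable from compound 1 to compound 2 is unreadable.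

The new compound 4 `O=C(CSc1nnnn1-c1cccc2ccccc12)N/N=C/c1ccccc1O` changes the group on the carbon with a double bond to nitrogen: 2-hydroxyphenyl in place of thiophen-2-yl on a carbon with a double bond to nitrogen. The measured steps all swap that same group and stay within the scatter or are unreadable, as seen in an at least 1.5-fold lower number from compound 2 to compound 3 (0.18 log units; that floor lies within the scatter) as well. Compound 4 is therefore expected to sit near compound 1, with an at least 1.2-fold lower number from compound 1 to compound 4 (0.08 log units; that floor lies within the scatter) expected to be within the scatter, and the estimate for compound 4 is 260000 nM with a range of 140000 nM to 450000 nM.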

Compound 4, half-maximal cytotoxic concentration: 4850 nM
For compound 4 the middle estimate is 54-fold (1.73 log units) above the measured one; the whole stated range lies above it.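

In this assay, the group on the carbon with a double bond to nitrogen proves able to shift the read-out strongly: 2-hydroxyphenyl gives an at least 65-fold lower number from compound 1 to compound 4 (1.81 log units; beyond the scatter), and the same kind of swap gives an at least 60-fold lower number from compound 2 to compound 4 (1.78 log units; beyond the scatter). Against the only earlier compound with a true number, the change is a 39-fold lower number from compound 3 to compound 4 (1.60 log units; beyond the scatter), so this group stands apart from the three earlier ones, and the lower number here means higher toxicity in this test. The first two steps are floors, as the values of compound 1 and compound 2 are limits of the assay and not numbers.

The compounds shown cannot separate the hydroxy group from the phenyl ring that carries it, a question that plain phenyl or 2-methoxyphenyl in the same place would address. Nothing shown here explains the size of this drop.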